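A few compounds are considered here, and "the series" means these few. Any claim that something is new, unique, unknown or untested is made for them only; others in the source may bear on it.

For the measured compounds named here, compound 1 `O=C(Nc1cccc(F)c1)c1cncc(N2CC3CC(C2)N3)c1` carries a 3-fluorophenyl on the amide and, in an assay on cells for displacement of a labelled ligand from Neuronal acetylcholine receptor; alpha3/beta4 (Homo sapiens) (on this read-out higher numbers stand for weaker inhibition and lower numbers for stronger inhibition), compound 1 gives 28 nM, the lowest of the two numbers so far. Compound 2 `O=C(c1cncc(N2CC3CC(C2)N3)c1)N1CCCc2ccccc21` gives 62 nM in this assay, a higher number, beyond the scatter. The next step keeps the core of compound 1 and puts chloro in place of fluoro on an aromatic carbon, giving compound 3 `O=C(Nc1cccc(Cl)c1)c1cncc(N2CC3CC(C2)N3)c1`. Going by the values given here, no measured pair so far shows this change, so no direction can be read from the data. The expected step from compound 1 to compound 3 in this assay is a 1.3-fold lower number from compound 1 to compound 3 (0.10 log units; within the scatter), none beyond the scatter. Compound 3 is estimated at 22 nM in this assay, within 9 nM to 60 nM.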

Compound 3, inhibition constant: 59 nM
Beside the measured number, compound 3's estimate is 2.7-fold (0.43 log units) below it, within the range that was stated.
By their numbers in this assay, from the lowest: compound 1; then compounds 3 and 2 (each within the scatter of the next).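

For the compounds shown here, the 3-fluorophenyl to 3-chlorophenyl change is the first single-place comparison, and in this assay it gives a 2.1-fold higher number from compound 1 to compound 3 (0.32 log units; beyond the scatter) as a modest step. The aromatic carbon carrying the halogen is therefore not indifferent to which halogen sits there, and fluoro holds the lower number of this pair. No evidence on the compounds bears on what lies behind this step.

Open, from the compounds shown here alone, is how hydrogen, methoxy, an amine or a carboxylic acid on this carbon would compare with fluoro and chloro. Also open, going by these compounds, is whether the step from fluoro to chloro recurs on other carbons of that ring.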